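Side chain on the aromatic oxygen of the shared core

The source may hold more compounds than are shown below. What is called first, only, known or untested is meant among the compounds shown, and "the series" means these compounds.

Compound 1 `O=c1c(-c2ccc(F)cc2)c[nH]c2ccnc(Nc3ccc(Oc4ccnc5cc(OCCO)ccc45)c(F)c3)c12` and compound 2 `O=c1c(-c2ccc(F)cc2)c[nH]c2ccnc(Nc3ccc(Oc4ccnc5cc(O)ccc45)c(F)c3)c12` share one core and differ only at an oxygen on an aromatic ring. In a functional assay on MKN-45 cells (Homo sapiens) for antiproliferative activity, read by MTT assay, with a stated time of 72 h (on this read-out lower numbers stand for stronger inhibition and higher numbers for weaker inhibition), compound 1 gives 4700 nM, and compound 2 gives 5000 nM. Within the data shown here, the step of a 1.1-fold higher number from compound 1 to compound 2 (0.03 log units; within the scatter) is the only measured step so far. Compound 2 thus holds the higher of the two numbers, but its distance to compound 1 is within the scatter, so no order between the two can be drawn.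

Compound 3 `COCCOc1ccc2c(Oc3ccc(Nc4nccc5[nH]cc(-c6ccc(F)cc6)c(=O)c45)cc3F)ccnc2c1` is not yet measured. It differs from compound 2 by 2-methoxyethyl in place of hydrogen on an oxygen on an aromatic ring. Among the measured compounds shown here, the one step that bears on this change is a 1.1-fold higher number from compound 1 to compound 2 (0.03 log units; within the scatter), where a 2-hydroxyethyl on the same oxygen left the number within the scatter. A 2-methoxyethyl at that place is therefore expected to give a step of a 1.1-fold lower number from compound 2 to compound 3 (0.05 log units; within the scatter) that also stays within the scatter. For compound 3 in this assay the estimate is 4500 nM, with a range from 2000 nM to 10000 nM.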

Compound 3, half-maximal inhibitory concentration: 5600 nM
Beside the measured number, compound 3's estimate is 1.2-fold (0.09 log units) below it, and the stated range covers the measured number.
By their numbers in this assay, from the lowest: compounds 1, 2 and 3 (each within the scatter of the next).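

In this assay, 2-methoxyethyl in place of hydrogen on the aromatic oxygen gives a 1.1-fold higher number from compound 2 to compound 3 (0.05 log units; within the scatter), so a second chain at this oxygen also leaves the number within the scatter of the free hydroxy compound. Methyl in place of hydrogen on the chain-end oxygen gives a 1.2-fold higher number from compound 1 to compound 3 (0.08 log units; within the scatter), which shows that, among these three compounds, capping the end of the chain does not separate the numbers either. No measurement at hand accounts for how closely the three compounds agree.

From the compounds shown here alone, it remains open whether a terminal amine, a carboxylic acid or a longer chain on this oxygen would move the number beyond the scatter in this assay. The three compounds also leave open whether changes elsewhere on the shared core would do so.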